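The source may report more compounds than this note shows. Statements on the series, on what has been measured and on what is new or still open speak of the compounds shown alone.

Working notes on the series. In an assay for activation of interferon regulatory factor 3 (Homo sapiens), read by a luciferase reporter, with a stated time of 20 h (a lower number here means that less compound is needed, a higher number that more compound is needed for the effect), compound 1 `CCCn1c(NC(=O)c2cncn2C)nc2cc(C(N)=O)cc(OC)c21` gives only a limit, > 100000 nM. In this assay compound 2 `COc1cc(C(N)=O)cc2nc(NC(=O)c3nccc4ccccc34)n(CCCNC(=O)OCc3ccccc3)c12` likewise reaches only the limit > 100000 nM. Compound 3 `COc1cc(C(N)=O)cc2nc(NC(=O)c3ccnn3C)n(CCCNC(=O)OCc3ccccc3)c12` stands at the limit > 100000 nM in this assay as well. The step that the two limits leave unreadable from compound 2 to compound 3 cannot be read, since the limit of > 100000 nM in this assay, at which 3 of the 3 values shown sit, covers every value shown. Compound 4 `COc1cc(C(N)=O)cc2nc(NC(=O)c3cncn3C)n(CCCNC(=O)OCc3ccccc3)c12` differs from compound 3 by 1-methyl-1H-imidazol-5-yl in place of 1-methyl-1H-pyrazol-5-yl on a carbonyl carbon. Within the data shown here, no measured step is readable for this change. The expectation for compound 4 rests on compound 1, which carries the same 1-methyl-1H-imidazol-5-yl group and gives only the limit > 100000 nM. The step expected is a number no higher from compound 3 to compound 4 (the limit leaves the size open), none beyond the scatter. The estimate for compound 4 in this assay is 100000 nM, between 30000 nM and 300000 nM, most probably again only a limit.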

Compound 4, half-maximal effective concentration: > 100000 nM
Compound 4 ended at the assay's limit; the forecaster's own chance of this, stated with the estimate: 85%; the middle value sits exactly at the limit.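

In this assay, among these compounds, no step linking compound 4 with compound 1, compound 2 or compound 3 can be read, since every value is a limit: the limit of > 100000 nM in this assay, at which 4 of the 4 values shown sit. The compounds shown leave open whether any group on the carbonyl carbon gives a readable value in this assay.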